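The source may report more compounds than this note shows. Statements on the series, on what has been measured and on what is new or still open speak of the compounds shown alone.

Compound 1 `Nc1cc(N)c2nc(-c3ccccc3)c(NCc3ccc(Cl)c(Cl)c3)nc2c1`: in a functional assay on SR cells (Homo sapiens) for inhibition, read by sulforhodamine B assay, with a stated time of 48 h (on this read-out higher numbers stand for weaker inhibition of growth and lower numbers for stronger inhibition of growth), compound 1 gives 6030 nM.
Compound 2 `CCOC(=O)[C@H](CCC(=O)O)NC(=O)c1ccc(Sc2nc3cc(N)cc(N)c3nc2-c2ccccc2)cc1`: in this assay compound 2 gives 81300 nM.

Compound 1 has the lowest number of the two; compound 2 is well beyond the scatter from it. Compound 3 `COc1ccc(CNc2nc3cc(N)cc(N)c3nc2-c2ccccc2)cc1` differs from compound 1 in one place: 4-methoxyphenyl in place of 3,4-dichlorophenyl on a saturated chain carbon bound to a nitrogen on an aromatic ring. Among the measured compounds shown here, no step between two measured compounds of this kind has been recorded, so no measured guide exists. The step from compound 1 to compound 3 in this assay is expected to be small, perhaps a slight weakening, and may stay within the scatter, a 1.5-fold higher number from compound 1 to compound 3 (0.17 log units; within the scatter). For compound 3 the expected value is 9000 nM, with a range from 2500 nM to 35000 nM.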

Compound 3, concentration for total growth inhibition: < 100000 nM
Compound 3 was reported as a limit; the forecaster's own chance of this, stated with the estimate: 5%; the middle value lies beyond the limit too.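

In this assay, among the compounds shown here, compound 3 gives < 100000 nM, which is a limit and not a number, so no step between compound 1 and compound 3 can be read. Going by these compounds, whether 4-methoxyphenyl in place of 3,4-dichlorophenyl changes growth inhibition, and in which direction, stays open.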